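A few compounds are considered here, and "the series" means these few. Any claim that something is new, unique, unknown or untested is made for them only; others in the source may bear on it.

Measured in a functional assay on T47D cells (Homo sapiens) for inhibition, read by CCK-8 assay, with a stated time of 72 h, tested at 10 uM; on this read-out lower numbers stand for less inhibition of growth and higher numbers for more inhibition of growth at the one concentration tested:
Compound 1 `CN(C)C(=O)c1cc2cnc(Nc3ccc(NC(=O)C4(C(=O)Nc5cccc(F)c5)CC4)cc3)nc2n1C1CCCC1`: -0.4%
Compound 2 `CN(C)C(=O)c1cc2cnc(Nc3ccc(NC(=O)C4(C(=O)Nc5cccc(Br)c5)CC4)cc3)nc2n1C1CCCC1`: 94.6%
Compound 3 `CN(C)C(=O)c1cc2cnc(Nc3ccc(NC(=O)C4(C(=O)Nc5ccc(C(F)(F)F)cc5)CC4)cc3)nc2n1C1CCCC1`: 94.9%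

Compound 3 stands level with compound 2, the gap being a number 0.3 percentage points higher from compound 2 to compound 3 (within the scatter) and far from compound 1, as shown by a number 95.3 percentage points higher from compound 1 to compound 3 (beyond the scatter) on the same read-out. Compound 4 `CN(C)C(=O)c1cc2cnc(Nc3ccc(NC(=O)C4(C(=O)Nc5ccc(O)cc5)CC4)cc3)nc2n1C1CCCC1` carries hydroxy in place of trifluoromethyl on an aromatic carbon at the same spot. For the measured compounds named here, no measured compound carries hydroxy, so the guide is indirect. Compound 1 and compound 2 show, through a number 95 percentage points higher from compound 1 to compound 2 (beyond the scatter), that one group on this ring can separate almost no inhibition from nearly full inhibition. A large fall is therefore expected, an estimated a number 59.9 percentage points lower from compound 3 to compound 4 (beyond the scatter) with much uncertainty. For compound 4 the expected value is 35% within an estimated range of -2% to 92% in this assay here.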

Compound 4, percent growth inhibition at one concentration: 95.8%
Beside the measured number, compound 4's estimate is 60.8 percentage points below it; the measured number lies above the stated range.
By their numbers in this assay, from the lowest: compound 1; then compounds 2, 3 and 4 (each within the scatter of the next).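

In this assay, for the compounds shown here, hydroxy in place of trifluoromethyl gives a number 0.9 percentage points higher from compound 3 to compound 4 (within the scatter) and so shows that a group with a hydrogen-bond donor, which none of the earlier compounds has on this ring, fits with strong growth inhibition. The 4-hydroxyphenyl group also stands level with 3-bromophenyl, at a number 1.2 percentage points higher from compound 2 to compound 4 (within the scatter) and remains far from 3-fluorophenyl, at a number 96.2 percentage points higher from compound 1 to compound 4 (beyond the scatter) so compound 1 is the only one of the four that goes against strong inhibition. No measurement here explains why such different groups give matching numbers.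

An amine or a carboxylic acid at the same spot could still behave differently. A single concentration also leaves open whether compound 2, compound 3 and compound 4 would separate at lower concentrations.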